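The source may hold more compounds than are shown below. What is called first, only, known or untested is meant among the compounds shown, and "the series" means these compounds.

Measured so far:
Compound 1, `CCCCCCc1cc2cn(Cc3cn(Cc4ccccc4)nn3)c(=O)nc2o1`, gives 68700 nM in a functional assay on HepG2 cells (Homo sapiens) for antiproliferative activity, read by MTT assay, with a stated time of 72 h; on this read-out higher numbers stand for weaker inhibition and lower numbers for stronger inhibition.
Compound 2, `O=c1nc2oc(C3CC3)cc2cn1Cc1cn(-c2ccc(Cl)cc2)nn1`, reaches only the assay limit > 100000 nM in this assay.

Compound 2 therefore stands at the edge of what this assay can report: no number was obtained for it, only a limit, (the limit of > 100000 nM in this assay, at which 1 of the 2 values shown sits). Compound 3, `O=c1nc2oc(C3CC3)cc2cn1Cc1cn(Cc2ccccc2)nn1`, differs from compound 2 by benzyl in place of 4-chlorophenyl on an aromatic nitrogen. Going by the values given here, no measured pair shows what this change does, so the size and direction of the step are open. Both measured compounds sit at the weak end of this assay, and nothing here points to a move toward strong inhibition. The step of an at least 1.1-fold lower number from compound 2 to compound 3 (0.04 log units; that floor lies within the scatter) is expected to be small, within the usual scatter, and starting from a limit it cannot be read as a firm change. Compound 3 is expected to give roughly 90000 nM, plausibly between 40000 nM and 200000 nM, with a fair chance that only a limit is reported again.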

Compound 3, half-maximal inhibitory concentration: 49100 nM
Beside the measured number, compound 3's estimate is 1.8-fold (0.26 log units) above it, and the stated range covers the measured number.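

Going by these compounds alone, the change from 4-chlorophenyl to benzyl on the aromatic nitrogen now has a first reading in this assay, and it gives an at least 2.0-fold lower number from compound 2 to compound 3 (0.30 log units; that floor lies within the scatter), so benzyl brings the series back to a measurable number, though the size of the step stays unknown. Compound 2 gave only a limit, so this step has a floor and no exact size: the limit of > 100000 nM in this assay, at which 1 of the 3 values shown sits.

With benzyl held on the nitrogen, cyclopropyl in place of hexyl on an aromatic carbon gives a 1.4-fold lower number from compound 1 to compound 3 (0.15 log units; within the scatter), so this swap shows no effect that can be told apart from repeat-measurement noise.

From the compounds shown here alone, it remains open whether the chlorine or the type of link to the ring drives the step, which a plain phenyl or a 4-chlorobenzyl group on that nitrogen could separate. Going by these compounds, it is also open whether an amine or a carboxylic acid on the benzyl ring would move the number far from the weak end of this assay.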